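Replacing pyridin-4-yl with 5-fluoro-2-hydroxyphenyl in compound 4

A few compounds are considered here, and "the series" means these few. Any claim that something is new, unique, unknown or untested is made for them only; others in the source may bear on it.

Three measured compounds share one core and differ only in the aryl group on the carbon with a double bond to nitrogen. Compound 1 `Cc1c(C(=O)N/N=C\c2ccccc2F)oc2cccc(O)c12` is measured in a functional assay on PC-3 cells (Homo sapiens) for inhibition (on this read-out higher numbers stand for weaker inhibition and lower numbers for stronger inhibition), where compound 1 gives >= 40000 nM, a limit of the assay rather than a number. Compound 2 `COc1ccccc1/C=N\NC(=O)c1oc2cccc(O)c2c1C` is measured in this assay, where compound 2 gives 32700 nM. Compound 3 `Cc1c(C(=O)N/N=C\c2ccncc2)oc2cccc(O)c12` is measured in this assay, where compound 3 gives >= 40000 nM, again a limit and not a number. Two of the three values therefore sit at the limit of >= 40000 nM in this assay, at which 2 of the 3 values shown sit, and the steps are an at least 1.2-fold lower number from compound 1 to compound 2 (0.08 log units; that floor lies within the scatter), an at least 1.2-fold higher number from compound 2 to compound 3 (0.08 log units; that floor lies within the scatter) and a step that the two limits leave unreadable from compound 1 to compound 3.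

Compound 4 `Cc1c(C(=O)N/N=C\c2cc(F)ccc2O)oc2cccc(O)c12` differs from compound 3 by 5-fluoro-2-hydroxyphenyl in place of pyridin-4-yl on a carbon with a double bond to nitrogen. For the measured compounds named here, the steps that bear on it, an at least 1.2-fold lower number from compound 1 to compound 2 (0.08 log units; that floor lies within the scatter) and an at least 1.2-fold higher number from compound 2 to compound 3 (0.08 log units; that floor lies within the scatter), both carry floors within the scatter, and no measured pair shows a hydroxy group on the phenyl ring. Compound 4 is therefore expected to stay weak in this assay, with a step of an at least 1.2-fold lower number from compound 3 to compound 4 (0.08 log units; that floor lies within the scatter) that need not exceed the scatter. Compound 4 is estimated at 33000 nM, between 12000 nM and 60000 nM.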

Compound 4, half-maximal inhibitory concentration: 3170 nM
Estimate against measurement, compound 4: 10-fold (1.02 log units) above; the whole stated range lies above it.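

In this assay, the aryl group on the carbon with a double bond to nitrogen now gives a large and readable change: 5-fluoro-2-hydroxyphenyl produces an at least 12-fold lower number from compound 3 to compound 4 (1.10 log units; beyond the scatter), as well as a 10-fold lower number from compound 2 to compound 4 (1.01 log units; beyond the scatter) and an at least 12-fold lower number from compound 1 to compound 4 (1.10 log units; beyond the scatter). The earlier steps between the 2-fluorophenyl, 2-methoxyphenyl and pyridin-4-yl compounds showed no readable change beyond the scatter, so this is the first evidence that the position can move the read-out, and compound 4 is the most potent of the four compounds shown. Two of the new steps give only a minimum size, because compound 1 and compound 3 each stand at a limit and not at a number: the limit of >= 40000 nM in this assay, at which 2 of the 4 values shown sit.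

The 5-fluoro-2-hydroxyphenyl group enters as a single change, so the compounds shown do not separate the part played by its hydroxy group from that of its fluoro group, and a plain 2-hydroxyphenyl would be needed to tell them apart. They also leave open how an amine or a carboxylic acid on the phenyl ring would read out at this position.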